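The source may hold more compounds than are shown below. What is called first, only, known or untested is meant among the compounds shown, and "the series" means these compounds.

Measured so far in an ADME assay on HCT-15 cells (Homo sapiens) for cytotoxicity; on this read-out higher numbers stand for an effect only at larger amounts of compound and lower numbers for an effect already at smaller amounts:
compound 1 `O=C1NC[C@@H](c2c[nH]c3ccccc23)N[C@H]1c1c[nH]c2ccccc12` gives > 10 ug/mL.
compound 2 `O=C(C1=NC(c2c[nH]c3cc(Br)ccc23)CN1)c1c[nH]c2ccccc12` gives 9.8 ug/mL.
compound 3 `O=C(C1=NC(c2c[nH]c3cc(Br)ccc23)CN1)c1c[nH]c2cc(Br)ccc12` gives 4.88 ug/mL.

For compound 1 the value is a limit of this assay, not a number, and it stands at the limit of > 10 ug/mL in this assay, at which 1 of the 3 values shown sits. Compound 2 and compound 3 share one core, compound 1 has another, and the difference between the two cores is not broken down here. Compound 3 differs from compound 2 by bromo in place of hydrogen on an aromatic carbon. That change gives a 2.0-fold lower number from compound 2 to compound 3 (0.30 log units; within the scatter), so compound 2 and compound 3 are not told apart by this assay.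

Compound 4 `O=C1NC[C@@H](c2c[nH]c3ccccc23)N[C@H]1c1c[nH]c2cc(Br)ccc12` is not yet measured. For the measured compounds named here, it differs from compound 1 by bromo in place of hydrogen on an aromatic carbon, the same change in the same place as the one between compound 2 and compound 3. For compound 4 a step of an at least 1.2-fold lower number from compound 1 to compound 4 (0.09 log units; that floor lies within the scatter) is expected, resting on the size of a 2.0-fold lower number from compound 2 to compound 3 (0.30 log units; within the scatter) and on compound 1 giving only a limit. The value expected for compound 4 is 8 ug/mL, with 4 ug/mL and 20 ug/mL as its ends. A limit again is possible.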

Compound 4, concentration for half-maximal effect: > 10 ug/mL
Compound 4: only a limit was reported; the forecaster's own chance of this, stated with the estimate: 40%; middle value at least 1.2-fold (0.09 log units) from the limit.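

Compound 4 gives > 10 ug/mL, which is a limit and not a number. Compound 1 also stands at a limit, so the effect of bromo in place of hydrogen on an aromatic carbon cannot be read between compound 1 and compound 4: the limit of > 10 ug/mL in this assay, at which 2 of the 4 values shown sit. The compounds shown leave open whether that change shifts the read-out on the core of compound 1 at all.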